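Trading isopropyl for 1-hydroxyethyl in compound 2

The compounds below may be only part of what the source reports. "The series", "measured", "known", "first", "only" and "open" are said of these compounds alone.

Values in an ADME assay on KB cells (Homo sapiens) for cytotoxicity, with a stated time of 48 h; on this read-out higher numbers stand for weaker inhibition and lower numbers for stronger inhibition:
- compound 1 `CC1=CCC[C@](C)(CC/C(C)=C/CC2=C(O)C(=O)C=C(N[C@H](C(=O)O)[C@@H](C)O)C2=O)[C@@H]1C`: > 10 ug/mL (a limit)
- compound 2 `C=C1[C@H](C)CCC[C@]1(C)CC/C(C)=C/CC1=C(O)C(=O)C=C(N[C@@H](C(=O)O)C(C)C)C1=O`: 6.2 ug/mL
- compound 3 `CC1=CCC[C@](C)(CC/C(C)=C/CC2=C(O)C(=O)C=C(N[C@@H](C(=O)O)[C@@H](C)O)C2=O)[C@@H]1C`: > 10 ug/mL (a limit)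

Within the data shown here, compound 2 gives the only exact number, 6.2 ug/mL. Compound 4 `C=C1[C@H](C)CCC[C@]1(C)CC/C(C)=C/CC1=C(O)C(=O)C=C(N[C@@H](C(=O)O)[C@H](C)O)C1=O` differs from it as follows: 1-hydroxyethyl in place of isopropyl on a saturated chain carbon bound to an amine nitrogen and a carbonyl carbon. Among the measured compounds shown here, the one measured step is a step that the two limits leave unreadable from compound 1 to compound 3, and it reflects (the fact that compounds 1 and 3 differ only in the configuration as drawn), so it offers no size to carry over. Compound 1 and compound 3 also carry 1-hydroxyethyl, on a core that differs from that of compound 2, and both are held by the limit of > 10 ug/mL in this assay, at which 2 of the 3 values shown sit. A move towards weaker inhibition in this assay is therefore expected: a 2.3-fold higher number from compound 2 to compound 4 (0.35 log units; beyond the scatter). For compound 4 the estimate is 14 ug/mL, with an expected range of 7 ug/mL to 30 ug/mL.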

Compound 4, half-maximal inhibitory concentration: > 10 ug/mL
Compound 4: a limit, no number (the forecaster's own chance of this, stated with the estimate: 65%); the middle value lies beyond the limit too.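

On the core of compound 2, the swap of isopropyl for 1-hydroxyethyl can now be compared directly in this assay, giving an at least 1.6-fold higher number from compound 2 to compound 4 (0.20 log units; that floor lies within the scatter). Compound 4 carries a limit rather than a number, so this step gives only a floor, and its true size could be small or large. Compounds with 1-hydroxyethyl on both cores now end at that limit, which leaves most of the set without an exact number: the limit of > 10 ug/mL in this assay, at which 3 of the 4 values shown sit.

From the compounds shown here alone, whether methyl, a longer chain or an amine at this place would give a readable value remains open. So does the effect of the opposite configuration at the 1-hydroxyethyl group on this core.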